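The source may hold more compounds than are shown below. What is called first, only, known or untested is meant among the compounds shown, and "the series" means these compounds.

Three members of this series have numbers in a functional assay on MCF7 cells (Homo sapiens) for inhibition, read by MTT assay, with a stated time of 72 h; on this read-out higher numbers stand for weaker inhibition and lower numbers for stronger inhibition. Compound 1, `O=C1Nc2ccc(F)cc2/C1=N/NC(=S)N1CCN(c2ccccc2)CC1`, gives 24300 nM in this assay. Compound 2, `O=C1Nc2cccc(Cl)c2/C1=N/NC(=S)N1CCN(c2ccccc2)CC1`, gives 52100 nM. Compound 3, `Cc1ccc(N2CCN(C(=S)N/N=C3\C(=O)Nc4ccc(Cl)cc43)CC2)c(C)c1`, gives 10800 nM, the lowest of the three numbers; its gap to compound 1 and its larger gap to compound 2 both lie beyond the scatter, so compound 3 shows the strongest inhibition of the three measured. No two of these compounds differ in a single place, so no isolated step can be read from them.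

Compound 4, `O=C1Nc2ccc(Cl)cc2/C1=N/NC(=S)N1CCN(c2ccccc2[N+](=O)[O-])CC1`, has not been measured in this assay. Against compound 3 the change is 2-nitrophenyl in place of 2,4-dimethylphenyl on an amine nitrogen in a ring. Nothing measured here isolates a change on the aryl group of the ring amine: compound 1 and compound 2 carry a plain phenyl there but also differ from compound 3 in the halogen on the shared core. Among the compounds with values here, the numbers give no basis for a step beyond the scatter in either direction, though the one member with the dimethylphenyl is also the one with the lowest number. Compound 4 is therefore expected near compound 3, with a modest drift toward a higher number, a 1.9-fold higher number from compound 3 to compound 4 (0.27 log units; within the scatter). The estimate for compound 4 in this assay is 20000 nM, within 7000 nM to 60000 nM.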

Compound 4, half-maximal inhibitory concentration: 7490 nM
Beside the measured number, compound 4's estimate is 2.7-fold (0.43 log units) above it; the range from low to high includes it.
By their numbers in this assay, from the lowest: compounds 4 and 3 (each within the scatter of the next); then compound 1; then compound 2.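

In this assay, within the data shown here, the aryl group on the ring amine now has its first isolated step (a 1.4-fold lower number from compound 3 to compound 4 (0.16 log units; within the scatter)), which the earlier compounds could not give, as none of them differ in a single place. On the shared core, 2-nitrophenyl and 2,4-dimethylphenyl read alike within the scatter, so the low number of compound 3 is not tied to the 2,4-dimethylphenyl group alone, and the two hydrogen-bond acceptors that enter with the 2-nitrophenyl group bring no step beyond the scatter at this position. No measurement shown offers an explanation for this result.

On these data alone, both aryl groups here are substituted six-membered carbon rings, so it remains open whether a pyridine ring, a benzyl group or an open alkyl chain on the same ring nitrogen would hold the number in this range or give a step beyond the scatter. Also open, as far as these compounds go, is how a carboxylic acid or an amine on the aryl ring would read, and whether the plain phenyl group carried by compound 1 and compound 2 would match these two on this same core.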